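This account rests on a few compounds, and the source may have more. Where it says the series, first, only, none or still open, it means among the compounds named here.

Measured so far in an ADME assay on microsomes from liver (Homo sapiens) for metabolic stability, read by LC-MS, using NADPH, with a stated time of 10 min, tested at 10 uM; on this read-out lower numbers stand for a shorter-lived compound and higher numbers for a longer-lived compound:
- compound 1 `Nc1ncnc2c1c(Oc1cc(C(F)(F)F)ccn1)nn2C1CCC1`: 1.02 h
- compound 2 `Nc1ncnc2c1c(Oc1cc(C(F)(F)F)ccn1)nn2[C@H]1C[C@H](F)C1`: 2.03 h
- compound 3 `Nc1ncnc2c1c(Oc1cc(C(F)(F)F)ccn1)nn2[C@H]1CC[C@@H](CO)CC1`: 1.6 h

Compound 3 stands second highest of the three numbers in this assay. Its nearest neighbour is compound 2, with a step of a 1.3-fold lower number from compound 2 to compound 3 (0.10 log units; within the scatter); its furthest is compound 1, with a step of a 1.6-fold higher number from compound 1 to compound 3 (0.20 log units; within the scatter). Neither step separates the compounds beyond the scatter.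

Compound 4 `Nc1ncnc2c1c(Oc1cc(C(F)(F)F)ccn1)nn2C1CCC(O)C1` differs from compound 3 by 3-hydroxycyclopentyl in place of 4-(hydroxymethyl)cyclohexyl on an aromatic nitrogen. The step that bears on this is the earlier change of the saturated ring on the aromatic nitrogen, a 1.6-fold higher number from compound 1 to compound 3 (0.20 log units; within the scatter), which stayed within the scatter; the fluoro change, a 2.0-fold higher number from compound 1 to compound 2 (0.30 log units; within the scatter), also stayed within the scatter. No step beyond the scatter is therefore expected in this assay for compound 4.

Compound 4 is expected at 1.5 h, between 0.8 h and 2.8 h. The expected step is a 1.1-fold lower number from compound 3 to compound 4 (0.03 log units; within the scatter).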

Compound 4, half-life: > 2.41 h
Compound 4 ended at the assay's limit; the forecaster's own chance of this, stated with the estimate: 5%; middle value at least 1.6-fold (0.20 log units) from the limit.
By their numbers in this assay, from the lowest: compounds 1, 3 and 2 (each within the scatter of the next). At a limit, above all of these: compound 4.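

In this assay compound 4 stands at a limit, not at a number: the limit of > 2.41 h in this assay, at which 1 of the 4 values shown sits. Even so, this position on the aromatic nitrogen now gives a change that clears the scatter, with 3-hydroxycyclopentyl replacing cyclobutyl: an at least 2.3-fold higher number from compound 1 to compound 4 (0.37 log units; beyond the scatter). Among these compounds, the floors of the other two comparisons, an at least 1.5-fold higher number from compound 3 to compound 4 (0.17 log units; that floor lies within the scatter) and an at least 1.1-fold higher number from compound 2 to compound 4 (0.07 log units; that floor lies within the scatter), settle no order among those compounds.

On these data alone, whether the hydroxyl or the five-membered ring carries the step from cyclobutyl stays open. As far as these compounds go, how an unsubstituted cyclopentyl or an aminocyclopentyl would read on this nitrogen also stays open.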